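Shortening the Hydroxamate Chain on a Second Core

A few compounds are considered here, and "the series" means these few. Any claim that something is new, unique, unknown or untested is made for them only; others in the source may bear on it.

Compound 2 `CC(C)CCc1c(OCCCCCCC(=O)NO)ccc2ccc(=O)oc12` and compound 1 `CC(C)CCc1c(OCCCCCC(=O)NO)ccc2ccc(=O)oc12` share one core, while compound 3 `CC(C)CCc1c(OCCCCCC(=O)NO)ccc2c1OC(=O)CC2` carries another; the difference between the two cores is not broken down here. In a functional assay on Hep 3B2 cells (Homo sapiens) for antiproliferative activity, read by sulforhodamine B assay, with a stated time of 48 h (a lower number here means a stronger inhibitor of growth, a higher number a weaker inhibitor of growth), compound 2 gives 750 nM. Compound 1 gives 800 nM in this assay, so the step of a 1.1-fold higher number from compound 2 to compound 1 (0.03 log units; within the scatter), described as hydroxycarbamoyl in place of (hydroxycarbamoyl)methyl on a saturated chain carbon, five bonds along the chain from an oxygen on an aromatic ring, leaves the number essentially unchanged. Compound 3 reaches only a limit in this assay, > 30000 nM. Compound 4 `CC(C)CCc1c(OCCCCC(=O)NO)ccc2c1OC(=O)CC2` is the unmeasured partner: hydroxycarbamoyl in place of (hydroxycarbamoyl)methyl on a saturated chain carbon, four bonds along the chain from an oxygen on an aromatic ring, the same kind of change as before, though here the group sits four bonds rather than five bonds along the chain from the oxygen on the aromatic ring. Because compound 3 sits at the limit of > 30000 nM in this assay, at which 1 of the 3 values shown sits, the step that the limit leaves unreadable from compound 3 to compound 4 is expected to be flat, resting on the flat measured step a 1.1-fold higher number from compound 2 to compound 1 (0.03 log units; within the scatter). Compound 4 is therefore expected to give 40000 nM in this assay, between 12000 nM and 120000 nM, most likely again reported only as a limit.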

Compound 4, concentration for 50% growth inhibition: > 30000 nM
Compound 4: only a limit was reported; the forecaster's own chance of this, stated with the estimate: 80%; the middle value lies beyond the limit too.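

Compound 3 and compound 4 both stand only at a limit, so no step between them can be read: the limit of > 30000 nM in this assay, at which 2 of the 4 values shown sit.

The compounds shown leave open whether hydroxycarbamoyl in place of (hydroxycarbamoyl)methyl changes growth inhibition at all on the core of compound 3.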